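Benzylidene variation on a shared sulfonamide ketone core

The compounds below may be only part of what the source reports. "The series", "measured", "known", "first", "only" and "open" are said of these compounds alone.

Compound 1 `O=C1/C(=C/c2ccc(Br)cc2)NS(=O)(=O)c2ccccc21` carries a 4-bromophenyl group and in an assay for inhibition of Intestinal-type alkaline phosphatase (Homo sapiens), read by spectrophotometry, with stated times of 10 min and 20 min (on this read-out higher numbers stand for weaker inhibition and lower numbers for stronger inhibition), compound 1 gives 3690 nM, the lowest of the three numbers recorded for this series. Compound 2 `O=C1/C(=C/c2ccc(Cl)cc2Cl)NS(=O)(=O)c2ccccc21` gives 4960 nM in this assay, a number within the scatter of compound 1, so the two cannot be put in order. Compound 3 `O=C1/C(=C/c2c(F)cccc2F)NS(=O)(=O)c2ccccc21` gives 10600 nM in this assay, a number beyond the scatter from compound 1. Among the measured compounds shown here, no pair among the three differs in one place only, so no single step can be read from the measured compounds.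

Compound 4 `O=C1/C(=C/c2cccc(O)c2)NS(=O)(=O)c2ccccc21` is not yet measured in this assay. It differs from compound 1 as follows: 3-hydroxyphenyl in place of 4-bromophenyl on a double-bonded chain carbon bound to a double-bonded ring carbon. For the measured compounds named here, nothing among the measured compounds shows what this change does, and the three numbers so far span a modest range, so the step from compound 1 to compound 4 is expected to be small, if anything toward a higher number, and probably not beyond the scatter, as a 1.5-fold higher number from compound 1 to compound 4 (0.17 log units; within the scatter) states. Compound 4 is estimated to give 5500 nM in this assay, with a range from 1800 nM to 17000 nM.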

Compound 4, half-maximal inhibitory concentration: 1210 nM
Compound 4: the middle estimate sits 4.5-fold (0.66 log units) above what was measured; the measured number lies below the stated range.
By their numbers in this assay, from the lowest: compound 4; then compounds 1 and 2 (each within the scatter of the next); then compound 3.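

In this assay, the position on a double-bonded chain carbon bound to a double-bonded ring carbon now has its first readable step: 3-hydroxyphenyl in place of 4-bromophenyl gives a 3.0-fold lower number from compound 1 to compound 4 (0.48 log units; beyond the scatter) on the shared core. The number therefore responds to a change at this position, and bromine is not required for the lower value: the entering group has 1 hydrogen-bond donor and 1 hydrogen-bond acceptor, where the leaving group has neither. No measured property is available to explain the step.

The change alters both the substituent and its printed ring number, so the two contributions cannot be separated. Compounds bearing 3-bromophenyl, 4-hydroxyphenyl, 3-methoxyphenyl or 3-aminophenyl groups would show whether the hydroxyl, its location or neither accounts for the lower number.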